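The source may report more compounds than this note shows. Statements on the series, on what has been measured and on what is new or still open speak of the compounds shown alone.

Measured in an ADME assay on cells (Hepatocyte, Mus musculus) for metabolic stability; on this read-out higher numbers stand for a longer-lived compound and lower numbers for a shorter-lived compound:
- Compound 1 `O=C(OC1CCC(CN2CCN(c3cc(=O)c4cc(C(F)(F)F)cc([N+](=O)[O-])c4s3)CC2)CC1)c1ccccc1`: 0.903 h
- Compound 2 `CC(=O)NC1CCC(CN2CCN(c3cc(=O)c4cc(C(F)(F)F)cc([N+](=O)[O-])c4s3)CC2)CC1`: > 1.55 h (a limit, not a number)

Compound 2 stands at the limit of > 1.55 h in this assay, at which 1 of the 2 values shown sits. Compound 3 `O=C(OC1CCC(CN2CCN(c3cc(=O)c4cc(C(F)(F)F)cc([N+](=O)[O-])c4s3)CC2)CC1)c1cccs1` carries ((thiophen-2-yl)carbonyl)oxy in place of acetamido on a saturated ring carbon. Among the measured compounds shown here, only one measured step bears on this change, an at least 1.7-fold higher number from compound 1 to compound 2 (0.23 log units; that floor lies within the scatter), which put acetamido in place of benzoyloxy on that same kind of carbon. Compound 3 gives up acetamido just as that step, read backwards, gives it up for benzoyloxy. A lower number in this assay is therefore expected, of about the size of that step, though it may not clear the scatter. Compound 1 gives 0.903 h, and this is the closest guide. The expected change is an at least 1.7-fold lower number from compound 2 to compound 3 (0.23 log units; that floor lies within the scatter). For compound 3 the estimate is 0.9 h, with an expected range from 0.45 h to 1.7 h.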

Compound 3, half-life: 0.0867 h
Beside the measured number, compound 3's estimate is 10-fold (1.02 log units) above it; measured number below the stated range.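

In this assay, ((thiophen-2-yl)carbonyl)oxy in place of acetamido on the saturated ring carbon gives an at least 17-fold lower number from compound 2 to compound 3 (1.25 log units; beyond the scatter), a large step, whereas the floor of the earlier step lay within the scatter. Compound 2 holds only a limit, so this step too is a floor: the limit of > 1.55 h in this assay, at which 1 of the 3 values shown sits. The two esters also part clearly, as thiophen-2-yl in place of phenyl on a carbonyl carbon gives a 10-fold lower number from compound 1 to compound 3 (1.02 log units; beyond the scatter), which shows that at this position the result depends on the ring on the carbonyl and not only on the ester link.

On these data alone, a thiophene-2-carboxamide at this carbon would separate what the thiophen-2-yl ring contributes from what the ester contributes, and that remains open. So does how a furan-2-yl or pyridinyl ester would compare with compound 1 and compound 3.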